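The compounds below may be only part of what the source reports. "The series", "measured", "known", "first", "only" and "open" are said of these compounds alone.

Measured compounds in the series:
compound 1 `COc1ccc(/C=C(/Sc2ccc(Br)cc2)C(=O)c2ccc(Br)cc2)cc1` gives 25000 nM;
compound 2 `COc1ccc(/C=C(/Sc2ccc(Br)cc2)C(=O)c2ccc(Br)cc2)c(F)c1` gives 20000 nM;
compound 3 `O=C(/C(=C\c1ccc(F)cc1Cl)Sc1ccc(Br)cc1)c1ccc(Br)cc1` gives 1000 nM.

All three were tested in a functional assay on DU-145 cells (Homo sapiens) for inhibition, read by trypan blue exclusion, with a stated time of 96 h; a higher number here means a weaker inhibitor of growth, a lower number a stronger inhibitor of growth. Compound 3 stands lowest of the three numbers: its nearest neighbour is compound 2, with a 20-fold lower number from compound 2 to compound 3 (1.30 log units; beyond the scatter), and its furthest is compound 1, with a 25-fold lower number from compound 1 to compound 3 (1.40 log units; beyond the scatter). The two methoxy-bearing rings sit close together, a 1.3-fold lower number from compound 1 to compound 2 (0.10 log units; within the scatter).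

The next compound, compound 4 `COc1cc(/C=C(/Sc2ccc(Br)cc2)C(=O)c2ccc(Br)cc2)ccc1F`, is not yet measured. It differs from compound 3 as follows: 4-fluoro-3-methoxyphenyl in place of 2-chloro-4-fluorophenyl on a double-bonded chain carbon bound to a double-bonded chain carbon. The step from compound 3 to compound 4 moves the ring back toward the methoxy-bearing pattern of compound 1 and compound 2 while keeping a fluorine, and also removes the chlorine. Going by the values given here, the two steps that bear on it, the one from compound 1 to compound 3 and the one from compound 2 to compound 3, were both large and both ran toward a lower number on arrival at the 2-chloro-4-fluorophenyl ring. Reversing part of that change is therefore expected to raise the number again, probably well beyond the scatter, though not necessarily all the way back, since compound 4 keeps a fluorine on the ring. Compound 4 is expected to give 10000 nM in this assay, within 2500 nM to 35000 nM, an estimated step of a 10-fold higher number from compound 3 to compound 4 (1.00 log units; beyond the scatter).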

Compound 4, concentration for 50% growth inhibition: 10000 nM
Compound 4: middle estimate and measured number agree at the digits printed; low and high end bracket the measured number.
By their numbers in this assay, from the lowest: compound 3; then compounds 4, 2 and 1 (each within the scatter of the next, the first and the last beyond it).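

In this assay, a ring holding a fluorine and no chlorine at this place does not keep the low number of compound 3 (a 10-fold higher number from compound 3 to compound 4 (1.00 log units; beyond the scatter)), so a fluorine alone does not account for that number. The 4-fluoro-3-methoxyphenyl ring falls with the other methoxy-bearing rings: it cannot be told apart from the 2-fluoro-4-methoxyphenyl ring (a 2.0-fold lower number from compound 2 to compound 4 (0.30 log units; within the scatter); within the scatter). Against the plain 4-methoxyphenyl ring it shows only a modest step (a 2.5-fold lower number from compound 1 to compound 4 (0.40 log units; beyond the scatter)).

The step from compound 3 to compound 4 removes the chlorine and adds the methoxy together, so the two changes cannot be separated here. As far as these compounds go, whether a 2-chlorophenyl ring, a 2,4-dichlorophenyl ring or a ring bearing an amine would hold the low number remains open. No evidence on the cause of these differences is available.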